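From aryl to cyclopentyl: a solubility step

The source may hold more compounds than are shown below. What is called first, only, known or untested is meant among the compounds shown, and "the series" means these compounds.

Measured in a physicochemical assay for solubility, read by HPLC, using the shake flask method, in phosphate buffer, with a stated time of 20 h, at pH 6.5; on this read-out higher numbers stand for higher solubility and lower numbers for lower solubility
- compound 1 `CN1CCN(C2CCN(c3nccc4[nH]c(-c5ccc(F)c(C(F)(F)F)c5)nc34)CC2)CC1` gives 195000 nM
- compound 2 `Fc1ccc(-c2nc3c(N4CCC(N5CCNCC5)CC4)nccc3[nH]2)cc1C(F)(F)F` gives 200000 nM
- compound 3 `CN1CCN(CC2CCN(c3nccc4[nH]c(-c5ccc(F)c(C(F)(F)F)c5)nc34)CC2)CC1` gives 165000 nM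

Compound 3 stands level with the other two, within the scatter of each (a 1.2-fold lower number from compound 1 to compound 3 (0.07 log units; within the scatter); a 1.2-fold lower number from compound 2 to compound 3 (0.08 log units; within the scatter)). Compound 4 `CN1CCN(CC2CCN(c3nccc4[nH]c(C5CCCC5)nc34)CC2)CC1` differs from compound 3 by a single change (cyclopentyl in place of 4-fluoro-3-(trifluoromethyl)phenyl on an aromatic carbon), cyclopentyl in place of 4-fluoro-3-(trifluoromethyl)phenyl on an aromatic carbon. The measured steps, including a 1.0-fold higher number from compound 1 to compound 2 (0.01 log units; within the scatter), all lay within the scatter, but none of them touches that aromatic carbon, so they bear on this change only indirectly. No step beyond the scatter is therefore expected in this assay, and the estimated step is small (a 1.2-fold higher number from compound 3 to compound 4 (0.08 log units; within the scatter)). Compound 4 is expected at 200000 nM, with an estimated range (120000 nM to 300000 nM).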

Compound 4, solubility: < 5000 nM
Compound 4: no number, only a limit; the forecaster's own chance of this, stated with the estimate: 35%; middle value at least 40-fold (1.60 log units) from the limit.
By their numbers in this assay, from the lowest: compounds 3, 1 and 2 (each within the scatter of the next). At a limit, below all of these: compound 4.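

At the aromatic carbon between two ring nitrogen atoms, cyclopentyl in place of 4-fluoro-3-(trifluoromethyl)phenyl gives an at least 33-fold lower number from compound 3 to compound 4 (1.51 log units; beyond the scatter) in this assay, the only step shown beyond the scatter, whereas the earlier changes on an amine nitrogen in a ring and on a saturated ring carbon left the numbers level. The result for compound 4 is a limit, so the full size of this step cannot be read: the limit of < 5000 nM in this assay, at which 1 of the 4 values shown sits.

The compounds shown leave open whether the step goes with the loss of the aromatic ring or with the loss of the fluorine and trifluoromethyl groups. Plain phenyl at this carbon, or a cyclopentyl carrying an amine, remains unaccounted for.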